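Replacing 1,3-thiazol-2-yl with phenyl on the shared core

A few compounds are considered here, and "the series" means these few. Any claim that something is new, unique, unknown or untested is made for them only; others in the source may bear on it.

Of the compounds shown here, three have been read so far in a functional assay on KB 3-1 cells (Homo sapiens) for cytotoxicity, read by MTT assay, with a stated time of 68 h; on this read-out lower numbers stand for stronger inhibition and higher numbers for weaker inhibition. For the measured compounds named here, compound 1 `Cc1ccccc1-c1cccc(NC(=O)C(Cl)Cl)c1` gives 42000 nM, the only actual number in the set. Compound 2 `COc1ccc(-c2cccc(NC(=O)C(Cl)Cl)c2)cc1` reports only a limit, > 50000 nM. Compound 3 `O=C(Nc1cccc(-c2nccs2)c1)C(Cl)Cl` likewise reports only a limit, > 50000 nM. Compound 3 therefore stands at the limit of > 50000 nM in this assay, at which 2 of the 3 values shown sit, and this gives no number from which to measure a step.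

Compound 4 `O=C(Nc1cccc(-c2ccccc2)c1)C(Cl)Cl` has not yet been measured. It carries phenyl in place of 1,3-thiazol-2-yl on an aromatic carbon of a six-membered aromatic ring of carbon only (phenyl in place of 1,3-thiazol-2-yl on an aromatic carbon). Going by the values given here, no pair of measured compounds isolates a single change, so this step has no direct precedent.

In this assay a small step towards stronger inhibition is expected, or none beyond the scatter. Among the compounds with values here, this expectation rests on compound 1 at 42000 nM, the only value in the set that is not a limit. A result reported only as a limit also remains quite possible for compound 4. The estimated change is an at least 1.2-fold lower number from compound 3 to compound 4 (0.09 log units; that floor lies within the scatter). For compound 4 the expected value is 40000 nM, with an estimated range of 15000 nM to 80000 nM.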

Compound 4, half-maximal inhibitory concentration: 46800 nM
Beside the measured number, compound 4's estimate is 1.2-fold (0.07 log units) below it; measured number inside the range.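

In this assay, hydrogen in place of methyl on an aromatic carbon gives a 1.1-fold higher number from compound 1 to compound 4 (0.05 log units; within the scatter), so removing the methyl group from compound 1 leaves the read-out unchanged within the scatter. Phenyl in place of 1,3-thiazol-2-yl gives an at least 1.0-fold lower number from compound 3 to compound 4 (0.02 log units; that floor lies within the scatter), and hydrogen in place of methoxy gives an at least 1.0-fold lower number from compound 2 to compound 4 (0.02 log units; that floor lies within the scatter), so compound 4 gives neither change a shift that can be told from the scatter. Compound 2 and compound 3 each report only a limit, which means that these two steps carry only a floor and no true size: the limit of > 50000 nM in this assay, at which 2 of the 4 values shown sit.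

It remains open whether any change on this aromatic ring can give clearly stronger inhibition in this assay, since the phenyl, methyl and methoxy variants shown give no step beyond the scatter. Also open, going by these compounds, is what an amine or a carboxylic acid would do in place of the phenyl group, and whether the two chlorine atoms of the amide side chain matter to the read-out.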